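The source may hold more compounds than are shown below. What is called first, only, known or untested is meant among the compounds shown, and "the series" means these compounds.

Values in a functional assay on the whole organism with Rattus norvegicus as the target; on this read-out higher numbers stand for an effect only at larger amounts of compound and lower numbers for an effect already at smaller amounts:
Compound 1 `COC(=O)Cn1c(=N)sc2cc(OC(F)(F)F)ccc21`: > 10 mg/kg
Compound 2 `CCSCCn1c(=N)sc2cc(OC(F)(F)F)ccc21`: 2.2 mg/kg
Compound 3 `C[S+]([O-])CCn1c(=N)sc2cc(OC(F)(F)F)ccc21`: 1.1 mg/kg

The entry for compound 1, > 10 mg/kg, is a limit of the assay. Compound 3 stands level with compound 2: a 2.0-fold lower number from compound 2 to compound 3 (0.30 log units; within the scatter). Compound 4 `C[S+]([O-])CCCn1c(=N)sc2cc(OC(F)(F)F)ccc21` differs from compound 3 by a group of 4 heavy atoms (2 carbon, 1 oxygen, 1 sulfur; no ring) in place of a group of 3 heavy atoms (1 carbon, 1 oxygen, 1 sulfur; no ring), on a saturated chain carbon, two bonds along the chain from an aromatic nitrogen, on a saturated chain carbon, two bonds along the chain from an aromatic nitrogen. Within the data shown here, no measured step makes this change alone. The larger steps, an at least 4.5-fold lower number from compound 1 to compound 2 (0.65 log units; beyond the scatter) and an at least 9.0-fold lower number from compound 1 to compound 3 (0.95 log units; beyond the scatter), both start from the limit of compound 1 and remove its methoxycarbonyl. The nearest exchange, reaching compound 3 from compound 2, gave a 2.0-fold lower number from compound 2 to compound 3 (0.30 log units; within the scatter). On that basis, only a small change, within the scatter, is expected: a 1.8-fold higher number from compound 3 to compound 4 (0.26 log units; within the scatter). The estimate for compound 4 is 2 mg/kg, with an expected range of 0.7 mg/kg to 6 mg/kg.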

Compound 4, dose for half-maximal effect: 2.3 mg/kg
Compound 4: middle estimate off by 1.2-fold (0.06 log units), on the low side; low and high end bracket the measured number.
By their numbers in this assay, from the lowest: compounds 3, 2 and 4 (each within the scatter of the next, the first and the last beyond it). At a limit, above all of these: compound 1.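

Among these compounds, putting the group of 4 heavy atoms in place of the group of 3 heavy atoms is the first change on this chain that moves the number beyond the scatter without starting from a limit: a 2.1-fold higher number from compound 3 to compound 4 (0.32 log units; beyond the scatter). The other comparison shows no difference: a 1.0-fold higher number from compound 2 to compound 4 (0.02 log units; within the scatter). The remaining step starts from a limit and gives only a bound, an at least 4.3-fold lower number from compound 1 to compound 4 (0.63 log units; beyond the scatter): the limit of > 10 mg/kg in this assay, at which 1 of the 4 values shown sits.

Going by these compounds, whether a still longer chain would raise the number further remains open. So does whether an amine or a carboxylic acid at this place would keep the effect at similar doses.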